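Nitro for Hydrogen on the Phenylpiperazine Arm

The compounds below may be only part of what the source reports. "The series", "measured", "known", "first", "only" and "open" are said of these compounds alone.

Compound 1 `S=c1oc(-c2ccc3c(c2)OCCO3)nn1CN1CCN(c2ccccc2)CC1` is the parent of this small series. In a functional assay on SW 1116 cells (Homo sapiens) for antiproliferative activity, read by MTT assay, with a stated time of 48 h (a lower number here means a stronger inhibitor, a higher number a weaker inhibitor), compound 1 shows only a limit of the assay, > 50000 nM; see (the limit of > 50000 nM in this assay, at which 1 of the 2 values shown sits). Compound 2 `COc1ccc(N2CCN(Cn3nc(-c4ccc5c(c4)OCCO5)oc3=S)CC2)cc1` carries a methoxy in place of hydrogen on an aromatic carbon and gives 24200 nM, a step of an at least 2.0-fold lower number from compound 1 to compound 2 (0.31 log units; beyond the scatter). Compound 3 `O=[N+]([O-])c1ccc(N2CCN(Cn3nc(-c4ccc5c(c4)OCCO5)oc3=S)CC2)cc1` bears the change (nitro in place of hydrogen on an aromatic carbon). Among the compounds with values here, only that methoxy step bears on it, so a similar modest step to a lower number is expected, an at least 2.0-fold lower number from compound 1 to compound 3 (0.30 log units; that floor lies within the scatter). Compound 3 is therefore estimated at 25000 nM, between 8000 nM and 50000 nM.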

Compound 3, half-maximal inhibitory concentration: > 50000 nM
Compound 3: only a limit was reported; the forecaster's own chance of this, stated with the estimate: 35%; middle value at least 2.0-fold (0.30 log units) from the limit.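

Para to a large group, the two substituents do not behave alike in this assay: nitro does not carry over the drop seen with methoxy, giving an at least 2.0-fold higher number from compound 2 to compound 3 (0.31 log units; beyond the scatter). Compound 3 gives > 50000 nM, which is a limit of the assay and not a number. The step between compound 1 and compound 3 cannot be read, and of the three compounds only compound 2 comes off that limit: the limit of > 50000 nM in this assay, at which 2 of the 3 values shown sit.

From the compounds shown here alone, whether an amine or a carboxylic acid at this place would also come off the limit stays open. So does how far compound 3 lies past its limit.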